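Swapping the aryl group of compound 3

This account rests on a few compounds, and the source may have more. Where it says the series, first, only, none or still open, it means among the compounds named here.

Compound 1 `CC1=CC[C@H](C(C)(C)N=C=S)CC1`: > 100000 nM in a functional assay on K562 cells (Homo sapiens) for inhibition, read by sulforhodamine B assay, with a stated time of 48 h (a lower number here means a stronger inhibitor of growth, a higher number a weaker inhibitor of growth), a limit of the assay.
Compound 2 `CC1=CC[C@H](C(C)(C)NC(=S)NN)CC1`: > 100000 nM, again a limit.
Compound 3 `COc1ccc(/C=N/NC(=S)NC(C)(C)[C@H]2CC=C(C)CC2)cc1`: 30700 nM.

Compound 1 reaches only the limit of this assay. Compound 2 also reaches only the limit. The step that the two limits leave unreadable from compound 1 to compound 2 is therefore unreadable. Compound 3 gives the only number shown; the other two values sit at the limit, as the limit of > 100000 nM in this assay, at which 2 of the 3 values shown sit, records.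

Compound 4 `CC1=CC[C@H](C(C)(C)NC(=S)N/N=C/c2ccccc2Cl)CC1` differs from compound 3 in one place: 2-chlorophenyl in place of 4-methoxyphenyl on a carbon with a double bond to nitrogen. Among the measured compounds shown here, no measured step touches this part of the molecule. For the measured compounds named here, the single measured step, a step that the two limits leave unreadable from compound 1 to compound 2, concerns a different part of the shared core and is unreadable, so it gives no guide to the size or direction of this change. With nothing to suggest otherwise, a step no larger than the usual scatter is the plainest expectation.

Compound 4 is therefore estimated at 30000 nM, with a likely range from 10000 nM to 100000 nM. The expected step of a 1.0-fold lower number from compound 3 to compound 4 (0.01 log units; within the scatter) stays within the scatter, and the upper end of that range touches the limit, so a limit rather than a number remains possible.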

Compound 4, concentration for total growth inhibition: 66200 nM
Beside the measured number, compound 4's estimate is 2.2-fold (0.34 log units) below it; low and high end bracket the measured number.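

In this assay, the group on the carbon with a double bond to nitrogen has a measurable effect on the read-out: 2-chlorophenyl in place of 4-methoxyphenyl gives a 2.2-fold higher number from compound 3 to compound 4 (0.33 log units; beyond the scatter), a modest loss of growth inhibition. Among the compounds shown here, this is the only step with a readable size, so this position is the one place where a single change can be put on a scale, and it shows that the choice of aryl group matters there, though only modestly. Nothing measured here explains why this swap weakens growth inhibition.

This one swap changes both the substituent on the phenyl ring and where it sits, so the compounds shown cannot tell which of the two accounts for the step. From the compounds shown here alone, what a 4-chlorophenyl or a 2-methoxyphenyl group would give on that same carbon remains open, as does whether a plain phenyl group, or an amine on the ring, would move the number in either direction.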